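Resolving the Ring Stereocentre in a Sigma Receptor Ligand

The compounds below may be only part of what the source reports. "The series", "measured", "known", "first", "only" and "open" are said of these compounds alone.

Compound 3 `CN(CCCCN1C(=O)OCC1c1ccccc1)Cc1ccc(Cl)cc1` gives 0.95 nM in an assay on cell membranes from Cerebral cortex for displacement of a labelled ligand from Sigma non-opioid intracellular receptor 1 (Cavia porcellus), read by scintillation counting, with a stated time of 120 min (on this read-out lower numbers stand for stronger inhibition and higher numbers for weaker inhibition), the lowest of the two numbers shown; compound 1 `CN(CCCCN1C(=O)OC[C@H]1c1ccccc1)Cc1ccc(Cl)cc1` gives 2.9 nM. Compound 2 `CN(CCCCN1CCCCC1=O)Cc1ccccc1` gives > 3000 nM in this assay, which is a limit of the assay and not a number. The step of a 3.1-fold lower number from compound 1 to compound 3 (0.48 log units; beyond the scatter) rests on (the fact that one of compounds 1 and 3 is drawn with a defined configuration and the other without, at the place where they differ). Compound 4 `CN(CCCCN1C(=O)OC[C@@H]1c1ccccc1)Cc1ccc(Cl)cc1` differs from compound 3 in one way: the two compounds have the same atoms and bonds; at least one stereo element is drawn with a configuration in one of them and without one in the other: 1 of 1 stereo elements differ; a stereocentre at a saturated ring carbon is drawn without a configuration in compound 3 and S in compound 4. Compound 3 is drawn without a configuration and gives the lower number, while compound 1 is drawn as R and gives the higher number 2.9 nM; the S form is therefore expected to carry the stronger binding. Compound 4 is expected at 0.6 nM (from 0.2 nM to 1.5 nM) in this assay, a step of a 1.6-fold lower number from compound 3 to compound 4 (0.20 log units; within the scatter) expected to stay within the scatter.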

Compound 4, inhibition constant: 9.3 nM
For compound 4 the middle estimate is 16-fold (1.19 log units) below the measured one; the whole stated range lies below it.
By their numbers in this assay, from the lowest: compound 3; then compound 1; then compound 4. At a limit, above all of these: compound 2.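

In this assay the S form does not bind more strongly than the R form: the switch gives a 3.2-fold higher number from compound 1 to compound 4 (0.51 log units; beyond the scatter), so the configuration at this saturated ring carbon does matter. Compound 3, drawn without a configuration, does not fall between the two defined forms, as shown by a 9.8-fold higher number from compound 3 to compound 4 (0.99 log units; beyond the scatter). The gap between the R and S forms rests on a single change: the fact that compounds 1 and 4 differ only in the configuration as drawn

The compounds shown do not explain why compound 3 gives a lower number than either defined form. From the compounds shown here alone, whether the R and S forms keep their order with a carboxylic acid or an amine at this ring carbon also remains open.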